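The compounds below may be only part of what the source reports. "The series", "measured", "known", "first", "only" and "open" are said of these compounds alone.

Measured compounds:
compound 1 `Brc1ccc(-c2cn3ccnc3c(-c3ccc4ncn(C5CCCCC5)c4c3)n2)cc1`: 9.4%
compound 2 `CCc1ccc(-c2cn3ccnc3c(-c3ccc4ncn(Cc5ccccc5)c4c3)n2)cc1`: 25%

Among the measured compounds shown here, in a functional assay on IGROV-1 cells (Homo sapiens) for inhibition, read by sulforhodamine B assay, with a stated time of 48 h, tested at 10 uM (on this read-out lower numbers stand for less inhibition and higher numbers for more inhibition at the one concentration tested (going by the name of the read-out)), compound 2 gives 25%, the higher of the two numbers measured so far. Compound 1, which gives 9.4%, lies below it by a margin beyond the usual scatter of repeated measurements. For the measured compounds named here, no pair of measured compounds differs in a single place, so the effect of exchanging one group on its own has not been observed yet. Compound 3 `c1ccc(Cn2cnc3ccc(-c4nc(-c5cccc6ccccc56)cn5ccnc45)cc32)cc1` has not been measured. It differs from compound 2 by naphthalen-1-yl in place of 4-ethylphenyl on an aromatic carbon. Going by the values given here, both the group that leaves and the group that enters are aromatic rings of carbon only, with no hydrogen-bond donors or acceptors, and no measured step points to a large shift in either direction. The step expected from compound 2 to compound 3 in this assay is a number 3 percentage points lower from compound 2 to compound 3 (within the scatter), within the scatter. For compound 3 the estimate in this assay is 22%, with a range from 5% to 45%.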

Compound 3, a percentage reported as inhibition, at one concentration (the size of the read-out at that concentration, not a potency): 11.3%
Beside the measured number, compound 3's estimate is 10.7 percentage points above it, and the stated range covers the measured number.
By their numbers in this assay, from the lowest: compounds 1 and 3 (each within the scatter of the next); then compound 2.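

In this assay, exchanging 4-ethylphenyl for naphthalen-1-yl gives the first change seen on its own, and the outcome is a number 13.7 percentage points lower from compound 2 to compound 3 (beyond the scatter) at this aromatic carbon. The position therefore does not treat these two all-carbon aromatic groups alike, even though neither has any hydrogen-bond donors or acceptors and the entering group differs by having 2 six-membered aromatic rings rather than one. Nothing measured alongside these numbers accounts for the difference.

The compounds shown leave open whether the second ring of naphthalen-1-yl or the absence of the ethyl group matters more, and a plain phenyl at this position would help separate the two. As far as these compounds go, it also remains open how a group carrying an amine or a carboxylic acid would read out here.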